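Chloro for Trifluoromethyl on a Methoxy-Bearing Core

This account rests on a few compounds, and the source may have more. Where it says the series, first, only, none or still open, it means among the compounds named here.

Compound 1 `N#Cc1cc(C(=O)N2CS(=O)(=O)c3ccccc32)cc(C(F)(F)F)c1O` is tested in an assay on tissue (RPTEC cells) for inhibition of solute carrier family 22 member 12 (Homo sapiens), read by scintillation counting, with stated times of 15 min and 2 h (on this read-out higher numbers stand for weaker inhibition and lower numbers for stronger inhibition), and gives > 100000 nM, which is a limit of the assay and not a number. Compound 2 `N#Cc1cc(C(=O)N2CS(=O)(=O)c3ccccc32)cc(Cl)c1O` likewise gives > 100000 nM in this assay, again a limit. Compound 3 `COc1cc(C(=O)N2CS(=O)(=O)c3ccccc32)cc(C(F)(F)F)c1O` differs from compound 1 by methoxy in place of cyano on an aromatic carbon. In this assay compound 3 gives 17800 nM, a step of an at least 5.6-fold lower number from compound 1 to compound 3 (0.74 log units; beyond the scatter). The change from compound 1 to compound 2 is chloro in place of trifluoromethyl on an aromatic carbon; its step is a step that the two limits leave unreadable from compound 1 to compound 2, since (the limit of > 100000 nM in this assay, at which 2 of the 3 values shown sit). Compound 4 `COc1cc(C(=O)N2CS(=O)(=O)c3ccccc32)cc(Cl)c1O` carries the same kind of change on the core of compound 3, namely (chloro in place of trifluoromethyl on an aromatic carbon), the place now being meta to a methoxy group rather than meta to a cyano group. Compound 4 is expected to move only a little, an expected step of a 1.1-fold higher number from compound 3 to compound 4 (0.05 log units; within the scatter), resting on a step that the two limits leave unreadable from compound 1 to compound 2 being unreadable. Compound 4 is thus estimated at 20000 nM, with a range from 7000 nM to 60000 nM.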

Compound 4, half-maximal inhibitory concentration: 4300 nM
The estimate for compound 4 lay 4.7-fold (0.67 log units) above the measured number, and the stated range ends above it.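

In this assay, chloro in place of trifluoromethyl gives a readable step on the methoxy-bearing core, a 4.1-fold lower number from compound 3 to compound 4 (0.62 log units; beyond the scatter). On the core of compound 1 the same change cannot be read, so the series does not show whether this step carries from one core to the other, and both cyano-bearing compounds rest on a limit of the assay: the limit of > 100000 nM in this assay, at which 2 of the 4 values shown sit. Methoxy in place of cyano goes the same way on both cores, with an at least 23-fold lower number from compound 2 to compound 4 (1.36 log units; beyond the scatter) on the chloro-bearing core, but the sizes of the two steps cannot be compared: the same change on two cores in this assay, an at least 5.6-fold lower number (0.74 log units; beyond the scatter) from compound 1 to compound 3 and an at least 23-fold lower number (1.36 log units; beyond the scatter) from compound 2 to compound 4; the limit leaves it open whether they differ.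

The compounds shown leave open how bromo or methyl would read in place of chloro. They also leave open what a longer chain in place of methoxy, or an amine in place of the hydroxy group, would do.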